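The source may report more compounds than this note shows. Statements on the series, on what has been measured and on what is new or still open speak of the compounds shown alone.

Measured compounds:
Compound 1, `N/C(=N\NC(=S)N1CCCCCC1)c1ccccn1`: 6000 nM
Compound 2, `N/C(=N\NC(=S)N1CCSCC1)c1ccccn1`: 7800 nM
Compound 3, `N/C(=N\NC(=S)N1CCSCC1)c1ccc(F)cn1`: 1700 nM

All three were tested in a functional assay on HeLa cells (Homo sapiens) for cytotoxicity, read by MTT assay, with a stated time of 72 h; on this read-out higher numbers stand for weaker inhibition and lower numbers for stronger inhibition. Compound 1 gives 6000 nM and compound 2 gives 7800 nM; these two numbers lie within the scatter of each other. The difference between the two cores of compound 1 and compound 2 is not broken down here. Compound 3 carries the change fluoro in place of hydrogen on an aromatic carbon relative to compound 2, and this brought a 4.6-fold lower number from compound 2 to compound 3 (0.66 log units; beyond the scatter).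

Compound 4, `N/C(=N\NC(=S)N1CCCCCC1)c1ccc(F)cn1`, has not yet been measured. Among the measured compounds shown here, it differs from compound 1 by fluoro in place of hydrogen on an aromatic carbon, the same change in the same place as the one that separates compound 3 from compound 2. Resting on that single earlier step, the same size of step is expected from compound 1 to compound 4, namely a 4.0-fold lower number from compound 1 to compound 4 (0.60 log units; beyond the scatter). Since compound 1 starts from 6000 nM, compound 4 is estimated to fall near 1500 nM, most likely between 600 nM and 4000 nM; this expectation rests on one comparison only.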

Compound 4, half-maximal inhibitory concentration: 900 nM
Compound 4: middle estimate off by 1.7-fold (0.22 log units), on the high side; the range from low to high includes it.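

In this assay, fluoro in place of hydrogen on an aromatic carbon gave a 6.7-fold lower number from compound 1 to compound 4 (0.82 log units; beyond the scatter) on the core of compound 1, in the same direction as on the core of compound 2. The two steps cannot be told apart, so in this assay the change carried over from one core to the other with no measurable difference in size: the same change on two cores in this assay, a 4.6-fold lower number (0.66 log units; beyond the scatter) from compound 2 to compound 3 and a 6.7-fold lower number (0.82 log units; beyond the scatter) from compound 1 to compound 4, 1.5-fold (0.16 log units) apart, within the scatter of two such steps. Among the compounds shown here, this rests on only two pairs, in a single cell assay and at a single place on the ring, so it does not show that the step would hold on any further core, nor does it explain why the number falls.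

Going by these compounds, it remains open whether chloro, methyl, methoxy or a nitrile at the same place would bring a step of similar size, and whether fluoro would do so elsewhere on the ring. Also open, on these data alone, is whether the step would be seen in cells other than those used here.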